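Swapping a pyridine substituent on a coumarin-like acid

The source may hold more compounds than are shown below. What is called first, only, known or untested is meant among the compounds shown, and "the series" means these compounds.

Compound 1, with the structure `C[C@@H](Oc1cc2oc(=O)n(CCC(=O)O)c2cc1Cl)c1ccc(Cl)cn1`, is a carboxylic acid that was tested in a physicochemical assay for permeability, using PAMPA (on this read-out lower numbers stand for lower permeability and higher numbers for higher permeability), and gave 60 nm/s. Compound 2, with the structure `O=C(O)CCn1c(=O)oc2cc(Cl)c(Cl)cc21`, is the other compound measured, and in this assay compound 2 gave 24 nm/s. Of these two numbers, compound 1 stands highest, and its gap to compound 2 lies beyond the scatter. Compound 3, with the structure `Cc1cccc([C@@H](C)Oc2cc3oc(=O)n(CCC(=O)O)c3cc2Cl)n1`, has not yet been measured. It differs from compound 1 in one place: 6-methylpyridin-2-yl in place of 5-chloropyridin-2-yl on a saturated chain carbon bound to an oxygen on an aromatic ring and a saturated chain carbon. Among the compounds with values here, since no step between measured compounds is known, the size of this change has to be judged from the structures alone. Neither the count of heavy atoms nor the count of hydrogen-bond donors and acceptors changes, so the step from compound 1 to compound 3 is expected to be small, within the scatter, as a 1.2-fold lower number from compound 1 to compound 3 (0.08 log units; within the scatter). Compound 3 is therefore expected to show about 50 nm/s, with a range from 25 nm/s to 100 nm/s.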

Compound 3, apparent permeability: 21 nm/s
For compound 3 the middle estimate is 2.4-fold (0.38 log units) above the measured one; measured number below the stated range.
By their numbers in this assay, from the lowest: compounds 3 and 2 (each within the scatter of the next); then compound 1.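

In this assay, the group on this saturated chain carbon clearly matters: 6-methylpyridin-2-yl in place of 5-chloropyridin-2-yl gives a 2.9-fold lower number from compound 1 to compound 3 (0.46 log units; beyond the scatter) on an otherwise unchanged molecule. The two groups have the same count of heavy atoms and the same counts of hydrogen-bond donors and acceptors, so these counts alone do not predict the read-out here. Within the data shown here, nothing measured so far explains this step.

The swap also changes two things at once, the kind of substituent on the pyridine ring and its number in the group's name, and these two compounds cannot separate one from the other. On these data alone, how a plain pyridin-2-yl group or a phenyl group would behave at this same position remains open.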